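Moving the methoxy on the anilino ring of compound 3

The source may hold more compounds than are shown below. What is called first, only, known or untested is meant among the compounds shown, and "the series" means these compounds.

The three measured compounds share one core and differ only in their aryl groups. Compound 1 `COc1cc(-c2nc(SCc3cn(CC(=O)NC(=O)Nc4ccccn4)nn3)nc(Nc3ccc(C)cc3)c2C#N)cc(OC)c1OC` in an ADME assay on GES1 cells (Homo sapiens) for inhibition, read by MTT assay, with a stated time of 72 h (a lower number here means a stronger inhibitor, a higher number a weaker inhibitor), gives only a limit, > 64000 nM. Compound 2 `Cc1ccc(-c2nc(SCc3cn(CC(=O)NC(=O)Nc4ccccn4)nn3)nc(Nc3ccc(C(C)C)cc3)c2C#N)cc1` likewise reaches only a limit in this assay, > 64000 nM. For the measured compounds named here, compound 3 `COc1ccc(Nc2nc(SCc3cn(CC(=O)NC(=O)Nc4ccccn4)nn3)nc(-c3ccc(C)cc3)c2C#N)cc1` is the one compound with a number: in this assay compound 3 gives 35700 nM. Going by the values given here, the only measured step is an at least 1.7-fold lower number from compound 2 to compound 3 (0.25 log units; that floor lies within the scatter), and its floor lies within the scatter. What frames the series is the limit of > 64000 nM in this assay, at which 2 of the 3 values shown sit.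

Compound 4 `COc1ccccc1Nc1nc(SCc2cn(CC(=O)NC(=O)Nc3ccccn3)nn2)nc(-c2ccc(C)cc2)c1C#N` differs from compound 3 by 2-methoxyphenyl in place of 4-methoxyphenyl on a nitrogen on an aromatic ring. Among the compounds with values here, no measured step moves a substituent around the ring in this way; the one step that touches the same ring, an at least 1.7-fold lower number from compound 2 to compound 3 (0.25 log units; that floor lies within the scatter), is small. The expected change a 1.3-fold higher number from compound 3 to compound 4 (0.10 log units; within the scatter) in this assay is therefore none beyond the scatter, with a fair chance that compound 4 again reaches only a limit. Compound 4 is estimated at 45000 nM, within 15000 nM to 130000 nM.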

Compound 4, half-maximal inhibitory concentration: > 64000 nM
Compound 4: no number, only a limit; the forecaster's own chance of this, stated with the estimate: 40%; at least 1.4-fold (0.15 log units) between middle value and limit.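

The change from 4-methoxyphenyl to 2-methoxyphenyl on a nitrogen on an aromatic ring is the first step shown that keeps the same atoms and only joins them differently, and in this assay it reads as an at least 1.7-fold higher number from compound 3 to compound 4 (0.25 log units; that floor lies within the scatter). For the compounds shown here, this gives only a floor, so the methoxy shift shows no change beyond the scatter, yet it leaves compound 3 as the only compound with a number, and the step between the two limits of compound 2 and compound 4 cannot be read. The series is still framed by one limit: the limit of > 64000 nM in this assay, at which 3 of the 4 values shown sit.

Going by these compounds, how large the values behind the limits are remains open. So does whether an amine or a carboxylic acid on this ring, in place of the methoxy, would give a clear number in this assay.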